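Ring-size and fusion changes on the amide carbonyl

A few compounds are considered here, and "the series" means these few. Any claim that something is new, unique, unknown or untested is made for them only; others in the source may bear on it.

Measured so far in an ADME assay for protein binding, using equilibrium dialysis, at pH 7.4, tested at 2 uM; a higher number here means a larger unbound share of the compound, a lower number a smaller unbound share:
- compound 1 `CC1CC=C(C(=O)N(c2cc(C#CC(C)(C)C)sc2C(=O)O)C(C)C)CC1`: 0.08
- compound 2 `CC(C)N(C(=O)C1CCCCC1)c1cc(C#CC(C)(C)C)sc1C(=O)O`: 0.18
- compound 3 `CC(C)N(C(=O)[C@H]1[C@@H]2CCCC[C@@H]21)c1cc(C#CC(C)(C)C)sc1C(=O)O`: 0.04

Compound 3 gives the lowest number of the three. Its nearest neighbour is compound 1, the gap a 2.0-fold lower number from compound 1 to compound 3 (0.30 log units; within the scatter) lying within the scatter; the gap to compound 2, a 4.5-fold lower number from compound 2 to compound 3 (0.65 log units; beyond the scatter), lies beyond it. Compound 4 `CC(C)N(C(=O)C1CCCCCC1)c1cc(C#CC(C)(C)C)sc1C(=O)O` differs from compound 3 only at the carbonyl carbon: a group of 7 heavy atoms (7 carbon; one seven-membered non-aromatic ring of carbon only) in place of a group of 7 heavy atoms (7 carbon; one three-membered non-aromatic ring of carbon only, one six-membered non-aromatic ring of carbon only), on a carbonyl carbon.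

Among the measured compounds shown here, the step that bears on this change is the one from compound 2 to compound 3, a 4.5-fold lower number from compound 2 to compound 3 (0.65 log units; beyond the scatter), where the fused three-membered ring entered on the cyclohexyl group. For the measured compounds named here, compound 4 removes that fused ring again but enlarges the single ring to seven members, so it sits between compound 2 and compound 3 in structure. The step from compound 1 to compound 2, a 2.3-fold higher number from compound 1 to compound 2 (0.35 log units; beyond the scatter), shows that changes of similar size on this carbonyl move the number by modest amounts. A modest rise from compound 3 is therefore expected, smaller than the full return to compound 2.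

Compound 4 is expected to give about 0.1 in this assay, within 0.05 to 0.2, corresponding to an estimated step of a 2.5-fold higher number from compound 3 to compound 4 (0.40 log units; beyond the scatter).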

Compound 4, unbound fraction: 0.11
The estimate for compound 4 lay 1.1-fold (0.04 log units) below the measured number; measured number inside the range.
By their numbers in this assay, from the lowest: compounds 3, 1, 4 and 2 (each within the scatter of the next, the first and the last beyond it).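

In this assay, cycloheptyl on the carbonyl carbon separates clearly from the fused group of compound 3 (a 2.8-fold higher number from compound 3 to compound 4 (0.44 log units; beyond the scatter)). Against the other two groups the change stays within the scatter, both for cycloheptyl in place of cyclohexyl (a 1.6-fold lower number from compound 2 to compound 4 (0.21 log units; within the scatter)) and for cycloheptyl in place of 4-methylcyclohex-1-en-1-yl (a 1.4-fold higher number from compound 1 to compound 4 (0.14 log units; within the scatter)). The single saturated rings of six and seven members therefore cannot be told apart at this position, while each lies beyond the scatter of the fused group; compound 1 goes against a clean split, lying within the scatter of both compound 3 and compound 4.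

No measurement at hand accounts for the difference between the fused group and cycloheptyl. Going by these compounds, whether cyclopentyl or tetrahydropyranyl on this carbonyl carbon would move the unbound fraction beyond the scatter remains open.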